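This account rests on a few compounds, and the source may have more. Where it says the series, first, only, none or still open, it means among the compounds named here.

Among the measured compounds shown here, in an ADME assay on cells (Homo sapiens) for cytotoxicity, read by resazurin assay, with a stated time of 5 days (a higher number here means that more compound is tolerated, a lower number that less compound is tolerated), only two compounds with the shared core have been measured, and neither gives a number. Compound 2 `COc1ccc(-c2nc(CS(=O)(=O)c3cccc(Cl)c3)nc3ccsc23)cn1` reads > 10000 nM, which is a limit of the assay. Compound 1 `COc1ccc(-c2nc(C(C)S(=O)(=O)c3cccc(Cl)c3)nc3ccsc23)cn1`, which carries a methyl on the same chain carbon, reads > 50000 nM, which is also a limit. Compound 2 therefore stands only at its limit, with no exact value to measure a change from.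

Compound 3 `COc1ccc(-c2nc(C(F)S(=O)(=O)c3cccc(Cl)c3)nc3ccsc23)cn1` alters that chain carbon once more: fluoro in place of hydrogen on a saturated chain carbon bound to an aromatic carbon and a sulfonyl sulfur. For the measured compounds named here, the one measured step on this carbon, with hydrogen in place of methyl, is a step that the two limits leave unreadable from compound 1 to compound 2. Going by the values given here, that step gives no size to carry over to fluoro, and no measured step involves fluoro itself. With so little to go on, no clear shift in either direction is expected in this assay, and compound 3 is expected to remain a well-tolerated compound that may also return only a limit. The estimated step is a step that the limit leaves unreadable from compound 2 to compound 3. For compound 3 the expected value is 25000 nM, with an estimated range from 10000 nM to 50000 nM.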

Compound 3, half-maximal cytotoxic concentration: > 50000 nM
Compound 3: no number, only a limit; the forecaster's own chance of this, stated with the estimate: 85%; at least 2.0-fold (0.30 log units) between middle value and limit.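

In this assay, compound 3 gives > 50000 nM, which is a limit of the assay, and the steps to it from compound 1 and from compound 2 cannot be read. The compounds shown leave open whether methyl, hydrogen or fluoro on this chain carbon makes any difference to the half-maximal cytotoxic concentration, and where that concentration lies for each.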